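Shifting the amine substituent from phenoxyalkyl to prenyl

The source may report more compounds than this note shows. Statements on the series, on what has been measured and on what is new or still open speak of the compounds shown alone.

In a functional assay on the whole organism (strain CD-1 Charles River) for inhibition, with Mus musculus as the target, in the writhing test, with stated times of 90 min and 5 min, at a dose of 25 mg/kg by the subcutaneous route (a lower number here means less inhibition, a higher number more inhibition at the dose given (going by the name of the read-out)), compound 2 `O=C1c2cc(Cl)ccc2Oc2ccccc2C12CCN(CCCOc1ccccc1)CC2` gives 54%, the higher of the two numbers measured. Its nearest neighbour, compound 1 `O=C1c2cc(Cl)ccc2Oc2ccccc2C12CCN(CC1CC1)CC2`, gives 31% in this assay. For the measured compounds named here, the one measured step, a number 23 percentage points higher from compound 1 to compound 2 (beyond the scatter), pairs a cyclopropyl with a 2-phenoxyethyl on the saturated chain carbon bound to the amine nitrogen in the ring. Compound 3 `CC(C)=CCN1CCC2(CC1)C(=O)c1cc(Cl)ccc1Oc1ccccc12` carries 2-methylprop-1-en-1-yl in place of 2-phenoxyethyl on a saturated chain carbon bound to an amine nitrogen in a ring, so the six-membered aromatic ring of carbon only and its hydrogen-bond acceptor leave, and a short chain with one double bond outside aromatic rings enters. That step bears some resemblance to the reverse of the measured one, since the entering group counts four heavy atoms, as the leaving cyclopropyl of compound 1 did. A modest drop in this assay is therefore expected, of the size a number 14 percentage points lower from compound 2 to compound 3 (beyond the scatter). Compound 3 is estimated at 40% in this assay, within a range from 20% to 60%.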

Compound 3, a percentage reported as inhibition, in the whole organism at one dose (the size of the read-out at that dose, not a potency): 42%
Compound 3: middle estimate off by 2 percentage points, on the low side, within the range that was stated.
By their numbers in this assay, from the lowest: compound 1; then compound 3; then compound 2.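

In this assay, the place on a saturated chain carbon bound to an amine nitrogen in a ring now has three groups to compare, and 2-methylprop-1-en-1-yl falls apart from both others: a number 12 percentage points lower from compound 2 to compound 3 (beyond the scatter), and a number 11 percentage points higher from compound 1 to compound 3 (beyond the scatter). A group with no ring and no hydrogen-bond acceptor can therefore raise the read-out over that of cyclopropyl, although neither the six-membered aromatic ring nor the acceptor of 2-phenoxyethyl is present, while 2-phenoxyethyl still gives the highest number of the three. No evidence is available to explain this order.

The compounds shown leave open whether the edge of compound 2 rests on its aromatic ring or its ether oxygen, a question a 4-phenylbutyl group in the same place would address. They also leave open whether the double bond of compound 3 matters, which a saturated 3-methylbutyl group would test.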